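This account rests on a few compounds, and the source may have more. Where it says the series, first, only, none or still open, it means among the compounds named here.

Of the compounds shown here, three have so far been tested in an assay on isolated protein for inhibition of leukotriene B4 receptor 1 (Homo sapiens), tested at 10 uM; a higher number here means more inhibition at the concentration tested (going by the name of the read-out), a lower number less inhibition. Compound 1 `CC(=O)c1cc(CC2CO2)c(OCCCCC#N)cc1O` gives 62%, compound 2 `CC(=O)c1cc(CO)c(OCCCCCCC#N)cc1O` gives 40%, and compound 3 `C=CCc1cc(C(C)=O)c(O)cc1OCC#N` gives 20%. Compound 3 therefore stands lowest of the three, with compound 2 nearest to it and compound 1 furthest; both of those gaps lie beyond the usual scatter of this measurement.

Compound 4 `C=CCc1cc(C(C)=O)c(O)cc1OCCCCCCC#N` differs from compound 3 in one place: 5-cyanopentyl in place of cyano on a saturated chain carbon bound to an oxygen on an aromatic ring. For the measured compounds named here, no single-change step between measured compounds is available to guide the guess, but compounds 1 and 2 both sit clearly above compound 3, so a rise beyond the scatter is expected, estimated as a number 25 percentage points higher from compound 3 to compound 4 (beyond the scatter). Compound 4 is accordingly expected to reach about 45%, within a range from 25% to 68%.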

Compound 4, a percentage reported as inhibition, at one concentration (the size of the read-out at that concentration, not a potency): 97%
Estimate against measurement, compound 4: 52 percentage points below; measured number outside the range, above it.
By their numbers in this assay, from the lowest: compound 3; then compound 2; then compound 1; then compound 4.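

At this position, on a saturated chain carbon bound to an oxygen on an aromatic ring, 5-cyanopentyl in place of cyano gives a number 77 percentage points higher from compound 3 to compound 4 (beyond the scatter) and so makes a large difference, although both groups carry a nitrile. The other place matters as well: with the 5-cyanopentyl chain kept, vinyl in place of hydroxy gives a number 57 percentage points higher from compound 2 to compound 4 (beyond the scatter) in the same assay. No measurement shown here explains either step. Still open, going by these compounds, is whether a longer chain, or a carboxylic acid in place of the nitrile, would keep this level of inhibition.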